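Replacing a Nitro with Two Methoxy Groups: Expected Potency

A few compounds are considered here, and "the series" means these few. Any claim that something is new, unique, unknown or untested is made for them only; others in the source may bear on it.

Compound 1 `CCc1cccc(C)c1-n1nncc1CN1C(=O)C2(C(C#N)=C(N)Oc3c(N)cc4nc5ccccc5nc4c32)c2ccccc21`: in a functional assay on MCF7 cells (Homo sapiens) for antiproliferative activity, read by MTT assay, with a stated time of 48 h (on this read-out higher numbers stand for weaker inhibition and lower numbers for stronger inhibition), compound 1 gives > 50000 nM, a limit rather than a number.
Compound 2 `N#CC1=C(N)Oc2c(N)cc3nc4ccccc4nc3c2C12C(=O)N(Cc1cnnn1-c1ccc([N+](=O)[O-])cc1[N+](=O)[O-])c1ccccc12`: in this assay compound 2 gives 20900 nM.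
Compound 3 `N#CC1=C(N)Oc2c(N)cc3nc4ccccc4nc3c2C12C(=O)N(Cc1cnnn1-c1ccc(Cl)cc1[N+](=O)[O-])c1ccccc12`: in this assay compound 3 gives > 50000 nM, again a limit.

On these data alone, compound 3 thus sits at the limit of > 50000 nM in this assay, at which 2 of the 3 values shown sit, the weakest end of what the assay reports, so its true value is unknown beyond that bound. Compound 4 `COc1cc(-n2nncc2CN2C(=O)C3(C(C#N)=C(N)Oc4c(N)cc5nc6ccccc6nc5c43)c3ccccc32)c(OC)cc1Cl` differs from it by 4-chloro-2,5-dimethoxyphenyl in place of 4-chloro-2-nitrophenyl on an aromatic nitrogen. Among the compounds with values here, no measured step tests a methoxy group. The nearest comparison, an at least 2.3-fold higher number from compound 2 to compound 3 (0.37 log units; beyond the scatter), shows that changing the group on this aromatic nitrogen can move the number at least modestly, while a step that the two limits leave unreadable from compound 1 to compound 3 stays unreadable because of the limit. With compound 3 already at the limit, compound 4 is expected to remain weak, with a number no higher from compound 3 to compound 4 (the limit leaves the size open) giving an estimate of 50000 nM (range 15000 nM to 150000 nM).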

Compound 4, half-maximal inhibitory concentration: > 50000 nM
Compound 4 ended at the assay's limit; the forecaster's own chance of this, stated with the estimate: 60%; the middle value lies on the limit itself.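

In this assay compound 4 gives > 50000 nM as a limit and not a number, so a ring with two methoxy groups on this aromatic nitrogen gives no readable potency. Placing 4-chloro-2,5-dimethoxyphenyl where 2,4-dinitrophenyl stood gives an at least 2.3-fold higher number from compound 2 to compound 4 (0.37 log units; beyond the scatter) on this read-out, leaving compound 2 as the only compound here with a readable number. The steps to compound 4 from compound 1 and compound 3 cannot be read, and the limit is now the common result: the limit of > 50000 nM in this assay, at which 3 of the 4 values shown sit.

On these data alone, how far compound 1, compound 3 and compound 4 truly lie apart stays open. Also open, as far as these compounds go, is whether an amine or a carboxylic acid on this phenyl ring would bring the number within the readable range.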